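The source may report more compounds than this note shows. Statements on the series, on what has been measured and on what is new or still open speak of the compounds shown alone.

Measured so far:
Compound 1 `Clc1ccc(COc2ccccc2/C=C/C(/C=C/c2ccccn2)=N/Oc2ncnc3cc(Cl)ccc23)c(Cl)c1` gives 23.6%
Compound 2 `Clc1ccc(COc2ccc(/C=C/C(/C=C/c3ccccn3)=N/Oc3ncnc4cc(Cl)ccc34)cc2)cc1` gives 67.4%
Compound 3 `Fc1ccccc1COc1ccccc1/C=C/C(/C=C/c1ccccn1)=N/Oc1ncnc2cc(Cl)ccc12` gives 94.2%

All three values come from a functional assay on SMMC-7721 cells (Homo sapiens) for inhibition, read by MTT assay, with a stated time of 72 h, tested at 1 uM; on this read-out higher numbers stand for a stronger effect at the one concentration tested and lower numbers for a weaker effect. Compound 1 stands lowest of the three, with compound 2 higher and compound 3 higher still, both beyond the scatter. Compound 4 `Cc1cccc2ncnc(O/N=C(\C=C\c3ccccn3)/C=C/c3ccccc3OCc3ccc(Cl)cc3Cl)c12` is not yet measured. It differs from compound 1 only in the group on the oxime oxygen: 5-methylquinazolin-4-yl in place of 7-chloroquinazolin-4-yl on an oxygen. Among the measured compounds shown here, the one measured step, a number 70.6 percentage points higher from compound 1 to compound 3 (beyond the scatter), exchanges the 2,4-dichlorophenyl on the saturated chain carbon and leaves the 7-chloroquinazolin-4-yl in place, so no measured step bears on the present change. The size of the step from compound 1 to compound 4 is accordingly uncertain; a small rise is expected, a number 11.4 percentage points higher from compound 1 to compound 4 (beyond the scatter), with a wide range. Compound 4 is expected at 35%, between 10% and 70%.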

Compound 4, a percentage reported as inhibition, at one concentration (the size of the read-out at that concentration, not a potency): 90.8%
Estimate against measurement, compound 4: 55.8 percentage points below; the measured number lies above the stated range.
By their numbers in this assay, from the lowest: compound 1; then compound 2; then compounds 4 and 3 (each within the scatter of the next).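

Exchanging 7-chloroquinazolin-4-yl for 5-methylquinazolin-4-yl on an oxygen gives a number 67.2 percentage points higher from compound 1 to compound 4 (beyond the scatter) in this assay, so this place alone can carry a large change in the read-out. The 2,4-dichlorophenyl group stays in place across this step, so its presence does not by itself keep the read-out as low as in compound 1. No measurement shown accounts for the step.

Still open, on these data alone, is whether the step follows from the entering methyl, the departing chlorine, or both. Quinazolin-4-yl without a substituent and 7-methylquinazolin-4-yl, on the same oxygen, would separate these.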